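The compounds below may be only part of what the source reports. "The series", "measured", "known", "first", "only" and "open" are said of these compounds alone.

Working notes on a short series read in an assay for inhibition of liver carboxylesterase 1 (Homo sapiens), read by spectrophotometry; on this read-out higher numbers stand for weaker inhibition and lower numbers for stronger inhibition. Compound 1 `O=C(O)c1ccc(S(=O)(=O)Nc2ccc(NS(=O)(=O)c3ccc(F)cc3)cc2)cc1` gives > 100000 nM in this assay, which is a limit of the assay and not a number. Compound 2 `O=S(=O)(Nc1ccc(NS(=O)(=O)c2ccc(Cl)cc2)c2ccccc12)c1ccc(Cl)cc1` gives > 100000 nM in this assay, again a limit. Compound 3 `O=S(=O)(c1ccccc1)N(c1ccccc1)c1ccccc1` gives > 100000 nM in this assay, also a limit. Within the data shown here, every value shown so far sits at the limit of > 100000 nM in this assay, at which 3 of the 3 values shown sit, so compound 1 stands nowhere distinct among the measured compounds and no measured step separates any pair. Compound 4 `Cc1ccc(C(=O)O)cc1S(=O)(=O)Nc1ccc(NS(=O)(=O)c2ccc(F)cc2)cc1` has not yet been measured; it differs from compound 1 by 5-carboxy-2-methylphenyl in place of 4-carboxyphenyl on a sulfonyl sulfur. Among the measured compounds shown here, with no measured step to lean on, the expected change is none beyond the scatter, a number no higher from compound 1 to compound 4 (the limit leaves the size open). Compound 4 is expected to give 100000 nM, within 30000 nM to 300000 nM, most likely again as a limit.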

Compound 4, inhibition constant: > 100000 nM
Compound 4: only a limit was reported (the forecaster's own chance of this, stated with the estimate: 85%); the middle value sits exactly at the limit.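

Compound 1 and compound 4 both stand only as limits, so no step can be read between them. The compounds shown leave open whether 5-carboxy-2-methylphenyl in place of 4-carboxyphenyl changes anything in this assay.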